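A Dichlorophenyl Carbonyl Swap Tested Against Lung Cancer Cells

The source may report more compounds than this note shows. Statements on the series, on what has been measured and on what is new or still open speak of the compounds shown alone.

Compound 2 `CN(C)c1ccc(C2CC(c3ccc(-n4ccnc4)cc3)=NN2C(=O)c2ccc(F)cc2)cc1` is one of two compounds for which a number is known in a functional assay on NCI-H1975 cells (Homo sapiens) for inhibition, read by sulforhodamine B assay, tested at 10 uM; a higher number here means more inhibition at the concentration tested (going by the name of the read-out), a lower number less inhibition. In this assay compound 2 gives -3.5%, the lower of the two numbers. The other measured compound, compound 1 `CN(C)c1ccc(C2CC(c3ccc(-n4cncn4)cc3)=NN2C(=O)c2cc(Cl)cc(Cl)c2)cc1`, differs from compound 2 in two places, and in this assay compound 1 gives 8.4%, a number that lies above that of compound 2 by a gap beyond the usual scatter. Since compound 1 and compound 2 differ in more than one place, nothing more can be drawn from their two values than that both stand low.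

Compound 3 `CN(C)c1ccc(C2CC(c3ccc(-n4ccnc4)cc3)=NN2C(=O)c2cc(Cl)cc(Cl)c2)cc1` is not yet measured. It differs from compound 2 in one place: 3,5-dichlorophenyl in place of 4-fluorophenyl on a carbonyl carbon. The part that enters in compound 3 is also found in compound 1, whose value stands higher than that of compound 2.

The step from compound 2 to compound 3 in this assay is expected to be small, upward if anything, and likely within the scatter, as a number 8.5 percentage points higher from compound 2 to compound 3 (within the scatter). Compound 3 is expected to give 5%, with a range from -10% to 20%.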

Compound 3, a percentage reported as inhibition, at one concentration (the size of the read-out at that concentration, not a potency): 58.7%
Estimate against measurement, compound 3: 53.7 percentage points below; the measured number lies above the stated range.
By their numbers in this assay, from the lowest: compound 2; then compound 1; then compound 3.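

In this assay, the position on the carbonyl carbon proves far more responsive than the earlier low values suggested: 3,5-dichlorophenyl in place of 4-fluorophenyl brings a number 62.2 percentage points higher from compound 2 to compound 3 (beyond the scatter). The 3,5-dichlorophenyl group is not enough on its own, since 1H-imidazol-1-yl in place of 1H-1,2,4-triazol-1-yl on an aromatic carbon, with that group held constant, brings a number 50.3 percentage points higher from compound 1 to compound 3 (beyond the scatter); among these compounds, the high number appears only in compound 3, which carries both the 3,5-dichlorophenyl and the 1H-imidazol-1-yl group, while compound 2 and compound 1 each carry just one of them. Nothing measured here accounts for either step.

The compounds shown leave open whether the step on the carbonyl carbon needs chlorine at all or would also appear with a 3,5-dimethylphenyl or 3,5-dimethoxyphenyl group, and whether a phenyl bearing a single chlorine would go part of the way. They also leave open how a morpholine in place of the dimethylamino group, which all three compounds share, would fare alongside the 3,5-dichlorophenyl and 1H-imidazol-1-yl groups.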